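Ring contraction at the amine of compound 3

The source may report more compounds than this note shows. Statements on the series, on what has been measured and on what is new or still open speak of the compounds shown alone.

Compound 1, `N#Cc1cnc(NCc2cnccc2C(F)(F)F)cc1NCC1CCOCC1`, gives 5000 nM in an assay on isolated protein for inhibition of protein kinase C delta type (Homo sapiens), read by TR-FRET, with a stated time of 2 h; on this read-out lower numbers stand for stronger inhibition and higher numbers for weaker inhibition.
Compound 2, `N#Cc1cnc(NCc2cnccc2C(F)(F)F)cc1NCCC1CCOCC1`, reaches only a limit, > 10000 nM, in this assay.
Compound 3, `N#Cc1cnc(NCc2cnccc2C(F)(F)F)cc1N[C@H]1CC[C@@H](C(N)=O)CC1`, gives 400 nM in this assay.

Compound 3 holds the lowest of the two numbers shown; its nearest neighbour is compound 1, with a 13-fold lower number from compound 1 to compound 3 (1.10 log units; beyond the scatter). From the limit of compound 2 the gap is an at least 25-fold lower number from compound 2 to compound 3 (1.39 log units; beyond the scatter), so both oxane-bearing chains sit well behind the 4-carbamoylcyclohexyl group.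

Compound 4, `CC1(C)[C@@H](Nc2cc(NCc3cnccc3C(F)(F)F)ncc2C#N)C[C@@H]1C(N)=O`, is the next entry for this assay. It differs from compound 3 by 3-carbamoyl-2,2-dimethylcyclobutyl in place of 4-carbamoylcyclohexyl on a nitrogen on an aromatic ring. The carbamoyl group and the saturated ring are kept, with the ring made smaller and two methyl groups added on it.

The steps measured so far, from compound 1 and compound 2 to compound 3, both exchange an oxane-containing chain for the carbamoyl ring, and both were large. Neither probes a change of ring size with the carbamoyl group retained, so they give no direct guide here. The expectation for compound 4 is therefore a step of a 1.5-fold higher number from compound 3 to compound 4 (0.18 log units; within the scatter), a small loss that may well fall within the scatter. Compound 4 is estimated at 600 nM, within 150 nM to 2500 nM.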

Compound 4, half-maximal inhibitory concentration: > 10000 nM
Compound 4: only a limit was reported (the forecaster's own chance of this, stated with the estimate: 5%); at least 16-fold (1.22 log units) between middle value and limit.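

In this assay, retaining the carbamoyl group on a saturated carbon ring does not preserve the result: 3-carbamoyl-2,2-dimethylcyclobutyl in place of 4-carbamoylcyclohexyl gives an at least 25-fold higher number from compound 3 to compound 4 (1.39 log units; beyond the scatter), so the carbamoyl group alone does not account for the lead of compound 3 over the two oxane-bearing compounds. Compound 4 reaches only a limit, > 10000 nM, which is a limit and not a number. The comparison on the oxane side gives an at least 2.0-fold higher number from compound 1 to compound 4 (0.30 log units; that floor lies within the scatter), a floor that places compound 4 no clearly beyond compound 1, and the step from compound 2 to compound 4 cannot be read because both values are limits: the limit of > 10000 nM in this assay, at which 2 of the 4 values shown sit.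

The smaller ring and the two methyl groups enter together, so the compounds shown do not assign the step to either change; a 3-carbamoylcyclobutyl group without the methyl groups, or a carbamoylcyclopentyl group, would separate them. Also open, from the compounds shown here alone, is whether the carbamoyl group itself is needed on the cyclohexyl ring, which a carboxylic acid or an amine at that place would test.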